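Aryl swap at the amide carbonyl on the weakest compound

The compounds below may be only part of what the source reports. "The series", "measured", "known", "first", "only" and "open" are said of these compounds alone.

Compound 1 `CCN1CCN(c2cc(C)c3cc(NC(=O)c4ccccc4F)ccc3n2)CC1` gives 32600 nM in a functional assay on MCF7 cells (Homo sapiens) for antiproliferative activity, read by MTT assay, with a stated time of 72 h (on this read-out higher numbers stand for weaker inhibition and lower numbers for stronger inhibition), the highest number of the three measured. Compound 3 `Cc1cc(N2CCCCC2)nc2ccc(NC(=O)c3ccc(Cl)c(Cl)c3)cc12` gives 31100 nM, within the scatter of compound 1. Compound 2 `Cc1cc(NCCN2CCN(C)CC2)nc2ccc(NC(=O)c3ccc(Cl)c(Cl)c3)cc12` gives 1700 nM. Among the measured compounds shown here, the only step between measured compounds, an 18-fold higher number from compound 2 to compound 3 (1.26 log units; beyond the scatter), concerns the group on the aromatic carbon, not the amide aryl, so it does not bear on the change at hand. Compound 4 `CCc1ccc(C(=O)Nc2ccc3nc(N4CCN(CC)CC4)cc(C)c3c2)cc1` differs from compound 1 by 4-ethylphenyl in place of 2-fluorophenyl on a carbonyl carbon. For the measured compounds named here, no measured pair isolates a change of the aryl on the carbonyl carbon; the expectation therefore rests on compound 1 alone, with a wide range. An essentially flat step is expected, a 1.3-fold lower number from compound 1 to compound 4 (0.12 log units; within the scatter). Compound 4 is estimated at 25000 nM, between 6000 nM and 90000 nM.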

Compound 4, half-maximal inhibitory concentration: 3060 nM
The estimate for compound 4 lay 8.2-fold (0.91 log units) above the measured number, outside the stated range (below it).
By their numbers in this assay, from the lowest: compounds 2 and 4 (each within the scatter of the next); then compounds 3 and 1 (each within the scatter of the next).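

In this assay, among the compounds shown here, the aryl on the carbonyl carbon proves to be a position that matters, a reading no earlier pair could give: 4-ethylphenyl in place of 2-fluorophenyl gives an 11-fold lower number from compound 1 to compound 4 (1.03 log units; beyond the scatter). The high number of compound 1 therefore does not belong to the rest of its structure alone. No measurement on hand accounts for this step.

The swap replaces fluorine with ethyl and alters the group's place on the phenyl ring together, so the two remain unseparated. A 4-fluorophenyl or 2-ethylphenyl group on the same carbonyl carbon would tell them apart.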